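The source may hold more compounds than are shown below. What is called first, only, known or untested is meant among the compounds shown, and "the series" means these compounds.

Measured in a functional assay on A549 cells (Homo sapiens) for inhibition, read by CCK-8 assay, with a stated time of 48 h; on this read-out higher numbers stand for weaker inhibition and lower numbers for stronger inhibition:
- Compound 1 `COc1cc(-c2ccnc3cc(-c4ccc(F)cc4)nn23)cc(OC)c1OC`: 3800 nM
- Compound 2 `COc1cc(-c2ccnc3cc(-c4cn(C)c5ccccc45)nn23)cc(OC)c1OC`: 1340 nM
- Compound 3 `C=Cc1ccc(-c2cc3nccc(-c4cc(OC)c(OC)c(OC)c4)n3n2)cc1`: 1030 nM

Compound 3 stands at the low end of these numbers, but not alone. The gap on one side is a 1.3-fold lower number from compound 2 to compound 3 (0.11 log units; within the scatter), while the gap on the other is a 3.7-fold lower number from compound 1 to compound 3 (0.57 log units; beyond the scatter). Compound 4 `COc1ccc(-c2cc3nccc(-c4cc(OC)c(OC)c(OC)c4)n3n2)cc1F` keeps the shared core and carries 3-fluoro-4-methoxyphenyl in place of 4-vinylphenyl on an aromatic carbon.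

Three measured steps change the group at this same place. One is a 2.8-fold lower number from compound 1 to compound 2 (0.45 log units; beyond the scatter), and the step to the vinyl compound, already given, is similar in size. Swapping this group has so far moved the number only modestly. Compound 4 loses the vinyl group and keeps a fluoro substituent, as does compound 1 at 3800 nM, so part of that modest gap may return. Going by the values given here, no measured compound carries the new group, so this comparison is only a rough guide. A small rise in the number is expected, and it may not clear the scatter. The estimated step is a 1.8-fold higher number from compound 3 to compound 4 (0.27 log units; within the scatter). For compound 4 the expected value is 1900 nM, with an estimated range from 800 nM to 4500 nM.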

Compound 4, half-maximal inhibitory concentration: 545 nM
Beside the measured number, compound 4's estimate is 3.5-fold (0.54 log units) above it, outside the stated range (below it).
By their numbers in this assay, from the lowest: compounds 4, 3 and 2 (each within the scatter of the next, the first and the last beyond it); then compound 1.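

In this assay, the vinyl group is not needed at this aromatic carbon of the five-membered ring: replacing 4-vinylphenyl with 3-fluoro-4-methoxyphenyl gives a step within the scatter (a 1.9-fold lower number from compound 3 to compound 4 (0.28 log units; within the scatter)), so compound 3 and compound 4 cannot be told apart. A fluorine on the phenyl ring also does not by itself keep the number high, since the new group clearly improves on both the 4-fluorophenyl group (a 7.0-fold lower number from compound 1 to compound 4 (0.84 log units; beyond the scatter)) and the 1-methyl-1H-indol-3-yl group (a 2.5-fold lower number from compound 2 to compound 4 (0.39 log units; beyond the scatter)), with both steps beyond the scatter. Nothing available here accounts for these differences.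

Going by these compounds, what remains open is whether the methoxy group or the fluorine on this ring matters more, a question that a plain 4-methoxyphenyl group at the same place could help to answer. Every group shown here is also built on an aromatic ring, so it is unknown how this position would respond to a non-aromatic group such as morpholine or to a group carrying a carboxylic acid.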